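Aminothiazole ketones: fluoro to methyl on the benzoyl ring

A few compounds are considered here, and "the series" means these few. Any claim that something is new, unique, unknown or untested is made for them only; others in the source may bear on it.

Measured so far in an assay for inhibition of Neuropeptide Y receptor type 5 (Mus musculus); on this read-out higher numbers stand for weaker inhibition and lower numbers for stronger inhibition:
compound 1 `COc1cccc(Nc2ncc(C(=O)c3ccccc3F)s2)c1` — 1000 nM
compound 2 `N#Cc1cccc(Nc2ncc(C(=O)c3ccccc3F)s2)c1` — 19 nM
compound 3 `Cc1cc(C(=O)c2cnc(Nc3cccc(C(F)(F)F)c3)s2)c(C)s1` — 395 nM

Compound 2 gives the lowest number of the three: compound 3 is higher by a wide margin, and compound 1 is higher still. Going by the values given here, the one single-point step available, a 53-fold lower number from compound 1 to compound 2 (1.72 log units; beyond the scatter), concerns the aniline ring and not the ketone side. Compound 4 `Cc1ccccc1C(=O)c1cnc(Nc2cccc(C#N)c2)s1` differs from compound 2 only on the ketone side: methyl in place of fluoro on an aromatic carbon. Among the compounds with values here, no measured pair isolates this change; compound 3 carries a different ketone ring but also a different aniline substituent, so its value cannot be assigned to either. Without a bearing step, a small move is expected, the direction uncertain, so for compound 4 an estimate of 40 nM (range 10 nM to 160 nM), meaning an expected step of a 2.1-fold higher number from compound 2 to compound 4 (0.32 log units; beyond the scatter) in this assay.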

Compound 4, half-maximal inhibitory concentration: 4.2 nM
Beside the measured number, compound 4's estimate is 9.5-fold (0.98 log units) above it; the measured number lies below the stated range.
By their numbers in this assay, from the lowest: compound 4; then compound 2; then compound 3; then compound 1.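

Going by these compounds alone, on the ketone side, methyl in place of fluoro gives a 4.5-fold lower number from compound 2 to compound 4 (0.66 log units; beyond the scatter) in this assay, the only single-place reading at this position. Fluoro is therefore not required for a low number here, and 2-methylphenyl does better than 2-fluorophenyl with the nitrile on the aniline ring. No evidence at hand bears on the reason for this step. From the compounds shown here alone, whether chloro, ethyl or methoxy at this position would go lower remains open, as does whether the methyl effect carries over to aniline rings bearing methoxy or trifluoromethyl.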